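The source may hold more compounds than are shown below. What is called first, only, known or untested is meant among the compounds shown, and "the series" means these compounds.

Measured so far in an assay on HEK293 cells for agonist activity at transient receptor potential cation channel subfamily M member 8 (Homo sapiens), read by fluorescence and calcium flux, with a stated time of 15 min; on this read-out higher numbers stand for an effect only at larger amounts of compound and lower numbers for an effect already at smaller amounts:

compound 1, `CCN(Cc1cccs1)C(=O)C(C)Oc1ccc(C)cc1`, gives 889 nM
compound 2, `CCN(Cc1ccccc1)C(=O)COc1ccc(C)cc1`, gives 1880 nM
compound 3, `CCN(Cc1cccs1)C(=O)COc1ccc(C#N)cc1`, gives 1990 nM

Compound 2 stands second highest of the three numbers. Its nearest neighbour is compound 3, whose number lies within the scatter of repeated measurement, so no order between compound 2 and compound 3 can be read from these values. Compound 1 stands furthest away, with a lower number than compound 2, and that gap lies beyond the scatter. Among the compounds with values here, no pair among the three differs in only one place, so no single step is available on which to lean.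

The next compound, compound 4, `CCN(Cc1cncs1)C(=O)COc1ccc(C)cc1`, is to be measured in this assay. Against compound 2 the change is 1,3-thiazol-5-yl in place of phenyl on a saturated chain carbon bound to an amide-type nitrogen. The ring that enters is counted with two hydrogen-bond acceptors where the ring that leaves has none, and it is smaller by one heavy atom.

Within the data shown here, with no comparable step among the measured compounds, the step from the value of compound 2 is expected to be small, within or just beyond the scatter, and if anything towards a higher number: a 1.3-fold higher number from compound 2 to compound 4 (0.12 log units; within the scatter) is the expected step. For compound 4 the estimate in this assay is 2500 nM, with a range from 1000 nM to 6300 nM.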

Compound 4, half-maximal effective concentration: 1100 nM
Beside the measured number, compound 4's estimate is 2.3-fold (0.36 log units) above it; the measured number falls inside the stated range.
By their numbers in this assay, from the lowest: compounds 1, 4, 2 and 3 (each within the scatter of the next, the first and the last beyond it).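

In this assay, the step from phenyl to 1,3-thiazol-5-yl on a saturated chain carbon bound to an amide-type nitrogen gives the only single-place comparison among the compounds shown, a 1.7-fold lower number from compound 2 to compound 4 (0.23 log units; within the scatter), so no difference between these two rings can be read at this position. The entering ring is smaller by one heavy atom and is counted with two hydrogen-bond acceptors where phenyl has none, yet the two values stay within the scatter of each other; this holds for one pair only and sets no trend for other rings. No supporting measurement bears on this result.

Going by these compounds, it remains open whether this position would accept a ring carrying an amine or a carboxylic acid, or a longer chain between the ring and the amide-type nitrogen. Compound 1 and compound 3 each differ from compound 4 in more than one place, so the 1,3-thiazol-5-yl group cannot yet be assessed alongside the branched chain of compound 1 or the nitrile of compound 3.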